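This account rests on a few compounds, and the source may have more. Where it says the series, first, only, none or still open, it means among the compounds named here.

Measured compounds:
- compound 1, `COc1ccccc1CNc1ncnc2c1ncn2[C@@H]1O[C@H](CO)[C@@H](O)[C@H]1O`, in a functional assay on HOS cells (Homo sapiens) for antiproliferative activity, with a stated time of 72 h (a higher number here means a weaker inhibitor, a lower number a stronger inhibitor), compound 1 gives > 166000 nM, a limit of the assay and not a number.
- compound 2, `COc1cc(CNc2ncnc3c2ncn3[C@@H]2O[C@H](CO)[C@@H](O)[C@H]2O)cc(OC)c1O`, in this assay compound 2 gives > 166000 nM, again a limit.
- compound 3, `COc1cc(O)cc(OC)c1CNc1ncnc2c1ncn2[C@@H]1O[C@H](CO)[C@@H](O)[C@H]1O`, in this assay compound 3 gives > 166000 nM, also a limit.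

Compound 1 therefore stands nowhere in particular on the numbers shown: all that is known of it in this assay is the limit, and the same holds for compound 2 and compound 3, as the limit of > 166000 nM in this assay, at which 3 of the 3 values shown sit, records. Going by the values given here, no step between two measured compounds can be read from these values, since none of them is a number.

The unmeasured compound 4, `Cc1ccc(O)c(CNc2ncnc3c2ncn3[C@@H]2O[C@H](CO)[C@@H](O)[C@H]2O)c1`, differs from compound 1 by 2-hydroxy-5-methylphenyl in place of 2-methoxyphenyl on a saturated chain carbon bound to a nitrogen on an aromatic ring. Among the compounds with values here, no measured pair shows what such a change does, so the account can lean only on the fact that every compound seen so far sits at the limit in this assay. Compound 4 is expected to behave in the same way, with the step that the limit leaves unreadable from compound 1 to compound 4 most likely amounting to no change beyond the scatter. Compound 4 is thus estimated at 200000 nM in this assay, within a range from 40000 nM to 1000000 nM.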

Compound 4, half-maximal inhibitory concentration: > 166000 nM
Compound 4 ended at the assay's limit (the forecaster's own chance of this, stated with the estimate: 80%); the middle value lies beyond the limit too.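

Going by these compounds alone, compound 1 and compound 4 both stand at a limit of the assay and not at a number, so no step between them can be read: the limit of > 166000 nM in this assay, at which 4 of the 4 values shown sit. The compounds shown leave open whether any compound built on the shared core would give a measurable value in this assay.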